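Shortening a Butyl Chain on a Slowly Permeating Acid

The compounds below may be only part of what the source reports. "The series", "measured", "known", "first", "only" and "open" are said of these compounds alone.

Measured so far:
compound 1, `CCCCc1nc2c(C)cc(C)nc2n1Cc1ccc(-c2c(C(=O)O)n(C)c(=O)c3ccccc23)cc1` — 0.01 10^-6 cm/s
compound 2, `CCc1nc2c(C)cc(C)nc2n1Cc1ccc(-c2c(-c3nn[nH]n3)cnc3ccccc23)cc1` — 0.1 10^-6 cm/s

Both numbers come from an ADME assay on Caco-2 cells (Homo sapiens) for permeability, in the apical to basolateral direction; a lower number here means that the compound crosses the layer more slowly, a higher number that the compound crosses the layer faster. Compound 1 stands at the lower of the two values; compound 2 gives a higher number, and that gap lies beyond the usual scatter of this assay. The two compounds differ in several places at once, so the gap cannot be tied to any single part of the structure.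

Compound 3, `CCc1nc2c(C)cc(C)nc2n1Cc1ccc(-c2c(C(=O)O)n(C)c(=O)c3ccccc23)cc1`, keeps the shared core of compound 1 with its carboxylic acid and differs from compound 1 in one place only: hydrogen in place of ethyl on a saturated chain carbon, two bonds along the chain from an aromatic carbon. Compound 2 also carries an ethyl at that position, yet its other differences from compound 1 mean its value says nothing firm about this chain on its own. Among the measured compounds shown here, no measured pair isolates this change, so the expectation rests on the size of the change alone: a small one, removing two carbons from a chain and nothing else. The step from compound 1 to compound 3 is expected to be small, a 1.5-fold higher number from compound 1 to compound 3 (0.18 log units; within the scatter), and not beyond the scatter. Compound 3 is therefore estimated at 0.015 10^-6 cm/s, with a likely range from 0.005 10^-6 cm/s to 0.05 10^-6 cm/s.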

Compound 3, apparent permeability: 0.03 10^-6 cm/s
Beside the measured number, compound 3's estimate is 2.0-fold (0.30 log units) below it; low and high end bracket the measured number.
By their numbers in this assay, from the lowest: compound 1; then compound 3; then compound 2.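

Among the compounds shown here, this is the first pair in the set that differs in one place only, so the chain can now be read on its own. With the shared core and its carboxylic acid held fixed, butyl to ethyl comes with a 3.0-fold higher number from compound 1 to compound 3 (0.48 log units; beyond the scatter) in this assay, which shows that this position is not silent and that removing two carbon atoms from the chain is enough to move the number past the usual scatter, though only by a modest step. No measurement here speaks to why the number moves, so the step stands as an observation without an explanation.

Going by these compounds, a single pair gives one step and not a trend, so it remains open whether a propyl or a methyl chain at this position would fall in line with butyl and ethyl, or whether a longer chain such as pentyl would continue the pattern in the other direction. On these data alone, it also remains open whether the same shortening would give a step of similar size on a core that carries no carboxylic acid.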